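The source may hold more compounds than are shown below. What is called first, only, known or untested is meant among the compounds shown, and "the series" means these compounds.

Working notes on the series. Compound 1 `C#CCOc1cc(O)c2c(c1)O[C@H](c1ccc(OC)c(O)c1)CC2=O` carries an ethynyl group on the chain oxygen of the shared core; in a functional assay on RAW264.7 cells (Mus musculus) for inhibition, read by Griess assay, with stated times of 2 h and 24 h (a higher number here means a weaker inhibitor, a lower number a stronger inhibitor), compound 1 gives 20900 nM. Compound 2 `CCCCn1cc(COc2cc(O)c3c(c2)O[C@H](c2ccc(OC)c(O)c2)C/C3=N\O)nn1`, which differs from the others at several places, gives 8900 nM in this assay. Compound 3 `COc1ccc([C@@H]2CC(=O)c3c(O)cc(OCc4cn(CC5CC5)nn4)cc3O2)cc1O` gives 11900 nM in this assay, which puts it second highest of the three numbers shown; compound 2 is nearest and compound 1 furthest, and both gaps lie within the scatter. Among the compounds with values here, the one single-change step known so far, a 1.8-fold lower number from compound 1 to compound 3 (0.24 log units; within the scatter), concerns the group on the chain carbon bound to the ring oxygen and was itself within the scatter.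

Compound 4 `COc1ccc([C@@H]2CC(=O)c3c(O)cc(OCc4cn(Cc5ccc(Cl)cc5)nn4)cc3O2)cc1O` is the next member. Its change from compound 3 is 4-chlorophenyl in place of cyclopropyl on a saturated chain carbon bound to an aromatic nitrogen. Within the data shown here, no measured pair varies this position alone, so none of the steps above bears directly on it; the only known step, from compound 1 to compound 3, moved the number within the scatter, and the two values of compounds 2 and 3 also sit within the scatter of each other. Among the measured compounds shown here, with no informative precedent, the expectation is a step of a 1.1-fold lower number from compound 3 to compound 4 (0.03 log units; within the scatter), which is no change beyond the scatter. Compound 4 is therefore estimated at 11000 nM in this assay, with a range from 4000 nM to 30000 nM.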

Compound 4, half-maximal inhibitory concentration: 17800 nM
Compound 4: middle estimate off by 1.6-fold (0.21 log units), on the low side, and the stated range covers the measured number.
By their numbers in this assay, from the lowest: compounds 2, 3, 4 and 1 (each within the scatter of the next, the first and the last beyond it).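

Within the data shown here, this is the first measured change at the group on the saturated chain carbon bound to an aromatic nitrogen: in this assay, going from cyclopropyl to 4-chlorophenyl gives a 1.5-fold higher number from compound 3 to compound 4 (0.17 log units; within the scatter), so the two compounds cannot be told apart. At this position, a three-membered non-aromatic ring of 3 heavy atoms and a six-membered aromatic ring with chlorine, 7 heavy atoms in all, thus give readings within the scatter of each other, a finding limited to this one pair. No measurement is available that would account for the size of this step.

An unsubstituted phenyl at this position would be needed to separate the contribution of the chlorine from that of the aromatic ring, and the compounds shown do not include that comparison. Also open, on these data alone, is whether a carboxylic acid or a dimethylamino group on this chain carbon would move the number beyond the scatter in this assay, since the two groups compared here leave that question untouched.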